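A few compounds are considered here, and "the series" means these few. Any claim that something is new, unique, unknown or untested is made for them only; others in the source may bear on it.

Compounds measured so far in an assay on HEK293 cells for inhibition of solute carrier family 22 member 12 (Homo sapiens); a lower number here means a stronger inhibitor, a higher number a weaker inhibitor:

- Compound 1, `O=S(=O)(O)CSc1nnc(Br)n1Cc1ccc(Br)c2ccccc12` — 14400 nM
- Compound 2, `O=S(=O)(CSc1nnc(Br)n1Cc1ccc(Br)c2ccccc12)Nc1cnccc1I` — 10600 nM

Compound 2 gives the lower of the two numbers in this assay, but its separation from compound 1 is small: the step of a 1.4-fold lower number from compound 1 to compound 2 (0.13 log units; within the scatter) lies within the scatter, so the two compounds are not distinguishable on these data.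

Compound 3, `COc1ncccc1NS(=O)(=O)CSc1nnc(Br)n1Cc1ccc(Br)c2ccccc12`, differs from compound 2 in one place: 2-methoxypyridin-3-yl in place of 4-iodopyridin-3-yl on a sulfonamide nitrogen. Going by the values given here, the only measured step that bears on this part of the molecule is the one from compound 1 to compound 2, in which the whole (4-iodopyridin-3-yl)amino group entered in place of hydroxy on the sulfonyl sulfur and the number moved by a 1.4-fold lower number from compound 1 to compound 2 (0.13 log units; within the scatter), a shift within the scatter. Since attaching the aryl amine at all changed little, exchanging one pyridinyl substituent for another at the same sulfonamide nitrogen is expected to change little as well, with no direction favoured beyond the scatter.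

Compound 3 is therefore expected to come out close to compound 2 in this assay, at roughly 11000 nM with a range of 4000 nM to 30000 nM, corresponding to an expected step of a 1.0-fold higher number from compound 2 to compound 3 (0.02 log units; within the scatter).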

Compound 3, half-maximal inhibitory concentration: 4050 nM
Beside the measured number, compound 3's estimate is 2.7-fold (0.43 log units) above it, within the range that was stated.
By their numbers in this assay, from the lowest: compound 3; then compounds 2 and 1 (each within the scatter of the next).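

In this assay, the sulfonamide nitrogen now proves to be a place where the choice of aryl group can register: putting 2-methoxypyridin-3-yl in place of 4-iodopyridin-3-yl gives a 2.6-fold lower number from compound 2 to compound 3 (0.42 log units; beyond the scatter) and is a modest change, though one beyond the scatter. The earlier comparison could not show this, since (4-iodopyridin-3-yl)amino in place of hydroxy on the sulfonyl sulfur gave a 1.4-fold lower number from compound 1 to compound 2 (0.13 log units; within the scatter), whereas (2-methoxypyridin-3-yl)amino in the same exchange gives a 3.6-fold lower number from compound 1 to compound 3 (0.55 log units; beyond the scatter), so replacing the hydroxy can separate a compound from compound 1 when the aryl group is the right one. Nothing in the data presented accounts for this difference between the two aryl groups.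

With only these two aryl groups compared, the compounds shown cannot tell whether the step comes from gaining the methoxy group, from losing the iodine, or from both, and a plain pyridin-3-yl, a 2-ethoxypyridin-3-yl or a 2-methoxyphenyl group on the same nitrogen would separate these readings. They also leave open whether the same holds with a different link to the sulfonyl sulfur, such as an ester oxygen or an N-methyl amine in place of the sulfonamide nitrogen.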